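Stereocentre inversion in the bis-fluorobenzyl amide series

The source may report more compounds than this note shows. Statements on the series, on what has been measured and on what is new or still open speak of the compounds shown alone.

Three compounds have numbers in a functional assay on HT-1080 cells (Homo sapiens), read by luminescence, with a stated time of 24 h; a higher number here means that more compound is needed for the effect, a lower number that less compound is needed. Compound 1 `CC1(C)CC(NC(=O)C/C=C/[C@H](NC(=O)OC(C)(C)C)c2ccccc2)CC(C)(C)N1` gives 1300 nM. Compound 2 `CC(C)C[C@@H](/C=C/C1(C(=O)NC2CC(C)(C)NC(C)(C)C2)CCOCC1)NC(=O)OC(C)(C)C` gives 2200 nM. Going by the values given here, compound 3 `CC1(C)CC(NC(=O)C(/C=C/[C@@H](NC(=O)OC(C)(C)C)c2ccc(F)cc2)(Cc2ccc(F)cc2)Cc2ccc(F)cc2)CC(C)(C)N1` gives 280 nM, the lowest of the three; its distance to compound 1 and to compound 2 is beyond the scatter in both cases, so compound 3 is the most potent compound measured so far.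

Compound 4 `CC1(C)CC(NC(=O)C(/C=C/[C@H](NC(=O)OC(C)(C)C)c2ccc(F)cc2)(Cc2ccc(F)cc2)Cc2ccc(F)cc2)CC(C)(C)N1` is the epimer of compound 3: the two compounds have the same atoms and bonds and differ only in configuration as drawn: 1 of 2 stereo elements differ; a stereocentre at a saturated chain carbon is drawn R in compound 3 and S in compound 4. Among the compounds with values here, no step between measured compounds of this kind is available, so the size of the effect of inverting this centre cannot be read from the data; compounds 1 and 2 carry different substitution and offer no matched comparison.

Inverting a stereocentre next to nothing else changed usually costs potency, so a move upward in this assay is expected, of uncertain size. For compound 4 the value in this assay is estimated at 1200 nM, with a range from 300 nM to 5000 nM. The expected step from compound 3 to compound 4 is a 4.3-fold higher number from compound 3 to compound 4 (0.63 log units; beyond the scatter), and it is expected to exceed the scatter.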

Compound 4, half-maximal effective concentration: 340 nM
Compound 4: the middle estimate sits 3.5-fold (0.55 log units) above what was measured, and the stated range covers the measured number.
By their numbers in this assay, from the lowest: compounds 3 and 4 (each within the scatter of the next); then compounds 1 and 2 (each within the scatter of the next).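

In this assay, inverting the saturated chain carbon gives a 1.2-fold higher number from compound 3 to compound 4 (0.08 log units; within the scatter), so the assay does not separate the R and S drawings at this centre. The comparison is clean, with nothing else to account for the outcome: the fact that compounds 3 and 4 differ only in the configuration as drawn. Going by these compounds alone, compounds 1 and 2 offered no matched reading of this kind, so this pair is the only direct look at the centre, and the result holds only for this substitution.

It remains open whether the configuration at this carbon would stay equally silent in compounds lacking the two fluorobenzyl groups, where no matched epimer pair is shown. Also open, as far as these compounds go, is whether a primary amine or an acetamide in place of the carbamate would leave the two configurations as close as they are here.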